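The source may hold more compounds than are shown below. What is called first, only, known or untested is meant among the compounds shown, and "the series" means these compounds.

Notes on the series. Within the data shown here, compound 3 `C=CCN(Cc1cccs1)C(=O)COc1ccc(C)cc1` gives 20 nM in an assay on HEK293 cells for agonist activity at transient receptor potential cation channel subfamily M member 8 (Homo sapiens), read by fluorescence and calcium flux, with a stated time of 15 min (on this read-out lower numbers stand for an effect already at smaller amounts and higher numbers for an effect only at larger amounts of compound), the second highest of the three numbers so far. Its nearest neighbour, compound 2 `CCN(Cc1cccs1)C(=O)COc1ccc(OC)cc1`, gives 120 nM in this assay, beyond the scatter above it; the furthest, compound 1 `COc1ccc2oc(C(=O)N(Cc3cccs3)c3ccn[nH]3)cc2c1`, gives 1.1 nM in this assay, beyond the scatter below it. Compound 4 `Cc1ccc(OCC(=O)N(Cc2cccs2)c2ccccn2)cc1` has not been measured in this assay. It differs from compound 3 by pyridin-2-yl in place of allyl on an amide-type nitrogen. Among the measured compounds shown here, no step of this kind exists among the measured compounds, and compound 1, the only one with a ring on the amide-type nitrogen, also has a different core, so it is no direct guide. A moderate downward step is expected, a 2.5-fold lower number from compound 3 to compound 4 (0.40 log units; beyond the scatter). For compound 4 in this assay the estimate is 8 nM, with a range from 2 nM to 40 nM.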

Compound 4, half-maximal effective concentration: 200 nM
Compound 4: the middle estimate sits 25-fold (1.40 log units) below what was measured; measured number outside the range, above it.
By their numbers in this assay, from the lowest: compound 1; then compound 3; then compounds 2 and 4 (each within the scatter of the next).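

Pyridin-2-yl in place of allyl on the amide-type nitrogen gives a 10-fold higher number from compound 3 to compound 4 (1.00 log units; beyond the scatter) in this assay and is the first step that can be read at this position. With the rest of the molecule unchanged, this aromatic ring goes with a higher number than the smaller allyl chain, not a lower one. Nothing measured here accounts for this step.

As far as these compounds go, it remains open whether the shift follows the ring itself or its nitrogen, which a plain phenyl on the same nitrogen would separate. Also open, from the compounds shown here alone, is whether a saturated group such as cyclopropyl would track allyl or pyridin-2-yl.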